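Working notes: from bromo to hydrogen on compound 2

This account rests on a few compounds, and the source may have more. Where it says the series, first, only, none or still open, it means among the compounds named here.

Compound 1 `CC(C)(C)NCc1c(C(=O)O)nn(-c2ccccc2)c1-c1ccccc1` gives a limit, not a number (> 716000 nM)
Compound 2 `CC(C)(C)NCc1c(C(=O)O)nn(-c2ccc(Cl)cc2)c1-c1ccc(Br)cc1` gives 542000 nM

For the measured compounds named here, in a functional assay on 786-0 cells (Homo sapiens) for inhibition, read by sulforhodamine B assay, with a stated time of 48 h (a lower number here means a stronger inhibitor of growth, a higher number a weaker inhibitor of growth), compound 2 holds the only actual number (542000 nM) of the two values. Compound 3 `CC(C)(C)NCc1c(C(=O)O)nn(-c2ccc(Cl)cc2)c1-c1ccccc1` carries hydrogen in place of bromo on an aromatic carbon, para to a large group (hydrogen in place of bromo on an aromatic carbon). Going by the values given here, no measured step speaks to this change, so the expectation rests on compound 2 (542000 nM). The step expected is no larger than the usual scatter, an estimated 1.2-fold higher number from compound 2 to compound 3 (0.08 log units; within the scatter) in this assay with no firm direction. Compound 3 is expected at 650000 nM with an estimated range from 380000 nM to 1000000 nM and may end up only as a limit.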

Compound 3, concentration for 50% growth inhibition: > 652000 nM
Compound 3: no number, only a limit; the forecaster's own chance of this, stated with the estimate: 45%; middle value at least 1.0-fold (0.00 log units) from the limit.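

In this assay, hydrogen in place of bromo on an aromatic carbon, para to a large group, gives an at least 1.2-fold higher number from compound 2 to compound 3 (0.08 log units; that floor lies within the scatter). Compound 3 gives only a limit, not a number: the limit of > 652000 nM in this assay, at which 1 of the 3 values shown sits.
For the compounds shown here, this is the first reading at this position, and its floor does not establish that bromo matters to growth inhibition. As far as these compounds go, the step between compound 1 and compound 3 cannot be read, since both values are limits, so the effect of chloro in place of hydrogen stays open. Also open, from the compounds shown here alone, is whether an amine or a carboxylic acid in place of bromo would give a lower number.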